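This account rests on a few compounds, and the source may have more. Where it says the series, first, only, none or still open, it means among the compounds named here.

Three compounds share a core in which a carboxamide-bearing thiophene ring is fused to a saturated ring carrying an amine nitrogen. Compound 1 `CCN1CCc2c(sc(NC(=O)[C@@H]3CCCN3)c2C(N)=O)C1` bears a pyrrolidine carboxamide on the thiophene and an ethyl group on that nitrogen. In a functional assay (strain AB) with Danio rerio as the target, read by microscopy, with a stated time of 1 h (a higher number here means that more compound is needed for the effect, a lower number that less compound is needed), compound 1 gives > 25000 nM, which is a limit of the assay rather than a number (the limit of > 25000 nM in this assay, at which 1 of the 3 values shown sits). Compound 2 `NC(=O)c1c(NC(=O)Nc2ccc(Cl)cc2)sc2c1CCN(CC1CCC1)C2` carries a chlorophenyl urea on the thiophene and a cyclobutylmethyl group on the ring nitrogen; in this assay compound 2 gives 1360 nM. Compound 3 `CC[N+]1(C)CCc2c(sc(NC(=O)Nc3ccc(Cl)cc3)c2C(N)=O)C1` keeps the same urea but has an ethyl and a methyl group on a now quaternary ring nitrogen, and in this assay compound 3 gives 1960 nM. The numbers of compound 2 and compound 3 lie within the usual scatter of each other, so neither stands apart; compound 2 holds one of the two measured numbers, the other compound giving only a limit.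

Compound 4 `CC(C)(C)OC(=O)CCN1CCc2c(sc(NC(=O)Nc3ccc(Cl)cc3)c2C(N)=O)C1` has not been measured in this assay. It differs from compound 2 by (tert-butoxycarbonyl)methyl in place of cyclobutyl on a saturated chain carbon bound to an amine nitrogen in a ring. The two measured ureas show that this position tolerates quite different groups without a step beyond the scatter, so for compound 4 the step from compound 2 is expected to be small, with a slight drift toward a higher number: a 1.6-fold higher number from compound 2 to compound 4 (0.21 log units; within the scatter). Compound 4 is therefore estimated to give 2200 nM in this assay, with a range from 700 nM to 7000 nM.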

Compound 4, half-maximal effective concentration: 1100 nM
Estimate against measurement, compound 4: 2.0-fold (0.30 log units) above, and the stated range covers the measured number.
By their numbers in this assay, from the lowest: compounds 4, 2 and 3 (each within the scatter of the next). At a limit, above all of these: compound 1.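

In this assay, the step is a 1.2-fold lower number from compound 2 to compound 4 (0.09 log units; within the scatter), so on a saturated chain carbon bound to an amine nitrogen in a ring, (tert-butoxycarbonyl)methyl can take the place of cyclobutyl without a change beyond the scatter. The four-membered ring of carbon leaves, and a group with no ring, 8 heavy atoms and 2 hydrogen-bond acceptors enters, so among the compounds shown neither that ring nor the lack of hydrogen-bond acceptors is needed here for a number in this range. Nothing measured here gives a reason why the number holds through this change.

Going by these compounds, whether it also holds for a carboxylic acid in place of the tert-butyl ester, for an amine at the end of the chain or for a longer chain remains open. Also open, on these data alone, is what the chlorophenyl urea contributes on its own: compound 1 gives > 25000 nM in this assay, which is a limit of the assay, and it differs from the other compounds in more than one place.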